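Adding tert-butyl to the benzoyl ring of compound 1

The compounds below may be only part of what the source reports. "The series", "measured", "known", "first", "only" and "open" are said of these compounds alone.

Compound 1 `CC(/C=N/Nc1ccc([N+](=O)[O-])cc1)=N\NC(=O)c1ccccc1` is the reference point of this set. In an ADME assay on J774 cells (Mus musculus, strain BALB/c) for cytotoxicity, read by resazurin assay, with a stated time of 72 h (a lower number here means that less compound is tolerated, a higher number that more compound is tolerated), compound 1 gives > 100000 nM, which is a limit of the assay rather than a number, so compound 1 stands only at that limit. Compound 2 `CC(/C=N/Nc1ccc([N+](=O)[O-])cc1)=N\NC(=O)c1ccccc1Nc1ccccc1` also returns a limit in this assay, at > 100000 nM. Compound 3 `CC(/C=N/Nc1ccc([N+](=O)[O-])cc1)=N\NC(=O)c1ccccc1F` likewise gives > 100000 nM, again a limit. Accordingly (the limit of > 100000 nM in this assay, at which 3 of the 3 values shown sit), and every step among these three is unreadable: a step that the two limits leave unreadable from compound 1 to compound 2, a step that the two limits leave unreadable from compound 1 to compound 3 and a step that the two limits leave unreadable from compound 2 to compound 3.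

Compound 4 `CC(/C=N/Nc1ccc([N+](=O)[O-])cc1)=N\NC(=O)c1ccc(C(C)(C)C)cc1` carries the change (tert-butyl in place of hydrogen on an aromatic carbon). Going by the values given here, no measured step speaks directly to a tert-butyl group, and the two measured substitutions on this ring, anilino and fluoro, both left the read-out at the limit without a readable size. The only expectation that can rest on these data is therefore no step beyond the scatter, and a number no higher from compound 1 to compound 4 (the limit leaves the size open) is what is estimated for the move from compound 1 to compound 4 in this assay. For compound 4 the expected value in this assay is 100000 nM, with a range from 30000 nM to 300000 nM, most probably again reported as a limit.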

Compound 4, half-maximal cytotoxic concentration: > 100000 nM
Compound 4 ended at the assay's limit; the forecaster's own chance of this, stated with the estimate: 80%; the middle value sits exactly at the limit.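

In this assay compound 4 gives > 100000 nM, which is a limit of the assay and not a number. Compound 1 also stands at a limit, so no step can be read between compound 1 and compound 4: the limit of > 100000 nM in this assay, at which 4 of the 4 values shown sit.

The compounds shown leave open whether anilino, fluoro or tert-butyl changes the concentration tolerated in this assay at all.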